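The source may hold more compounds than are shown below. What is called first, only, known or untested is meant among the compounds shown, and "the series" means these compounds.

The study concerns three measured compounds and a fourth that awaits measurement. Compound 1 `COc1cc(C2=C(c3cc(C)c(OC)c(C)c3)C(O)CC2=O)cc(OC)c1OC` bears a free hydroxy group on a saturated ring carbon. In an ADME assay on HEK293 cells (Homo sapiens) for cytotoxicity, read by MTT assay, with a stated time of 72 h (on this read-out higher numbers stand for weaker inhibition and lower numbers for stronger inhibition), compound 1 gives > 100 ug/mL, which is a limit of the measurement rather than a number. Compound 2 `COc1ccc(C2=C(c3cc(OC)c(OC)c(OC)c3)C(=O)C(OC(C)=O)C2)cc1O`, an acetoxy-bearing relative, gives 92 ug/mL in this assay. Compound 3 `COc1ccc(C2=C(c3cc(OC)c(OC)c(OC)c3)C(=O)C(O)C2)cc1NC(=O)c1ccccc1` gives > 100 ug/mL in this assay, again a limit. Among the compounds with values here, compound 1 therefore stands together with compound 3 at the limit of > 100 ug/mL in this assay, at which 2 of the 3 values shown sit, and no pair of measured compounds differs in a single place, so no measured step can be drawn from them. Compound 4 `COc1cc(C2=C(c3cc(C)c(OC)c(C)c3)C(OC(C)=O)CC2=O)cc(OC)c1OC` differs from compound 1 by acetyl in place of hydrogen on an oxygen on a saturated carbon. Given that compound 1 shows only a limit, the step from compound 1 to compound 4 is expected to be none beyond the scatter, a number no higher from compound 1 to compound 4 (the limit leaves the size open). Compound 4 is accordingly expected to give about 100 ug/mL in this assay, within a range from 50 ug/mL to 200 ug/mL, most likely reported again as a limit.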

Compound 4, half-maximal inhibitory concentration: > 100 ug/mL
Compound 4 gave a limit, no number; the forecaster's own chance of this, stated with the estimate: 65%; the middle value sits exactly at the limit.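

In this assay compound 4 gives > 100 ug/mL and this is a limit, not a number. Within the data shown here, compound 1 also shows only a limit, so no step between compound 1 and compound 4 can be read. The compounds shown leave open whether acetyl in place of hydrogen on that oxygen changes the read-out at all.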